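The compounds below may be only part of what the source reports. "The series", "measured", "known", "first", "only" and "open" are said of these compounds alone.

Measured compounds in the series:

compound 1, `C/C(=N\NC(=O)c1cccc(S(=O)(=O)N2CCOCC2)c1)c1cccc(N)c1`, > 100000 nM in a functional assay on PC-3 cells (Homo sapiens) for antiproliferative activity, read by MTT assay, with a stated time of 72 h; on this read-out higher numbers stand for weaker inhibition and lower numbers for stronger inhibition
compound 2, `C/C(=N\NC(=O)c1cccc(S(=O)(=O)N2CCOCC2)c1)c1ccccc1O`, 2810 nM in this assay
compound 3, `C/C(=N\NC(=O)c1cccc(S(=O)(=O)N2CCOCC2)c1)c1cc(Br)ccc1O`, 6890 nM in this assay

The value of compound 1 is a limit of this assay, not a number (the limit of > 100000 nM in this assay, at which 1 of the 3 values shown sits). Of the two numbers in hand, compound 3 carries the higher one, with a 2.5-fold higher number from compound 2 to compound 3 (0.39 log units; beyond the scatter) separating it from compound 2. The two large steps, an at least 35-fold lower number from compound 1 to compound 2 (1.55 log units; beyond the scatter) and an at least 14-fold lower number from compound 1 to compound 3 (1.16 log units; beyond the scatter), both run from a limit and fix only a floor for their size.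

Compound 4, `C/C(=N\NC(=O)c1cccc(S(=O)(=O)N2CCOCC2)c1)c1cc(F)ccc1O`, is not yet measured. It differs from compound 3 by fluoro in place of bromo on an aromatic carbon; the substituted carbon is meta to a large group and para to a hydroxy group.

Among the measured compounds shown here, only the step from compound 2 to compound 3 bears on this change: bromo in place of hydrogen at this carbon gave a 2.5-fold higher number from compound 2 to compound 3 (0.39 log units; beyond the scatter), a modest rise. Fluoro sits between hydrogen and bromo in size, so compound 4 is expected to land between compound 2 and compound 3, with a step of a 1.5-fold lower number from compound 3 to compound 4 (0.19 log units; within the scatter) that stays within the usual scatter. For compound 4 the estimate in this assay is 4500 nM, with a range from 2000 nM to 10000 nM.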

Compound 4, half-maximal inhibitory concentration: 4410 nM
Compound 4: middle estimate off by 1.0-fold (0.01 log units), on the high side; low and high end bracket the measured number.
By their numbers in this assay, from the lowest: compounds 2, 4 and 3 (each within the scatter of the next, the first and the last beyond it). At a limit, above all of these: compound 1.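

In this assay, fluoro in place of bromo at the carbon para to a hydroxy group gives a 1.6-fold lower number from compound 3 to compound 4 (0.19 log units; within the scatter), and fluoro in place of hydrogen at that carbon gives a 1.6-fold higher number from compound 2 to compound 4 (0.20 log units; within the scatter). Neither step clears the scatter, although a 2.5-fold higher number from compound 2 to compound 3 (0.39 log units; beyond the scatter) does, so compound 4 cannot be told apart from either neighbour and only the hydrogen and bromo compounds stand apart at this carbon. The fluoro compound also gives a number where compound 1 does not, but an at least 22-fold lower number from compound 1 to compound 4 (1.35 log units; beyond the scatter) runs from a limit of compound 1, which is not a number, and fixes only a floor for its size: the limit of > 100000 nM in this assay, at which 1 of the 4 values shown sits.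

As far as these compounds go, whether a group other than a halogen at this carbon, such as methoxy, nitrile or an amine, would move the number beyond the scatter from compound 2 remains open. Also open, from the compounds shown here alone, is what drives the large steps from compound 1, the exchange of the amino group for a hydroxy group or its place on the ring, and how a methoxy group in place of that hydroxy group would read.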